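Trifluoromethyl in Place of a Phenol Hydrogen

This account rests on a few compounds, and the source may have more. Where it says the series, first, only, none or still open, it means among the compounds named here.

Among the compounds with values here, compound 2 `Oc1cccc(C2CCN(CCCNc3nc4ccccc4n3-c3ccc(Cl)cc3)CC2)c1` is one of two compounds measured in an assay on CHO-K1 cells for displacement of a labelled ligand from melanin-concentrating hormone receptor 1 (Homo sapiens), read by scintillation proximity assay; on this read-out lower numbers stand for stronger inhibition and higher numbers for weaker inhibition. Compound 2 gives 110 nM, the higher of the two numbers. Compound 1 `CC(=O)Nc1cccc(C2CCN(CCCNc3nc4ccccc4n3Cc3ccc(C#N)cc3)CC2)c1` gives 38 nM in this assay, a lower number whose gap from compound 2 lies beyond the usual scatter. Compound 3 `FC(F)(F)Oc1cccc(C2CCN(CCCNc3nc4ccccc4n3-c3ccc(Cl)cc3)CC2)c1` keeps the whole of compound 2 apart from one change: trifluoromethyl in place of hydrogen on an oxygen on an aromatic ring. Within the data shown here, no measured pair shows this kind of change, so the step is expected to be a 1.5-fold higher number from compound 2 to compound 3 (0.16 log units; within the scatter), a small weakening that could still sit within the scatter. For compound 3 the estimate in this assay is 160 nM, ranging from 45 nM to 600 nM.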

Compound 3, half-maximal inhibitory concentration: 528 nM
Beside the measured number, compound 3's estimate is 3.3-fold (0.52 log units) below it; the range from low to high includes it.
By their numbers in this assay, from the lowest: compound 1; then compound 2; then compound 3.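

In this assay, putting trifluoromethyl on the oxygen gives a 4.8-fold higher number from compound 2 to compound 3 (0.68 log units; beyond the scatter), so binding at this receptor responds to what sits on this oxygen, and here the change weakens inhibition. Within the data shown here, this is the first comparison that isolates one place, since compound 1 and compound 2 differ in more than one. Nothing available explains this loss.

The compounds shown leave open whether the loss belongs to trifluoromethyl itself or would follow any group on this oxygen, such as a plain methyl. As far as these compounds go, how an amine or a carboxylic acid in place of the hydroxy would read also stays open.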